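This account rests on a few compounds, and the source may have more. Where it says the series, first, only, none or still open, it means among the compounds named here.

Values in an ADME assay on MCF-10A cells (Homo sapiens) for antiproliferative activity, read by MTT assay; a lower number here means a stronger inhibitor, a higher number a weaker inhibitor:

compound 1, `NS(=O)(=O)c1ccc(C(=O)N/N=C(/CS(=O)(=O)c2ccccc2)c2ccc(Cl)cc2)cc1`: 25600 nM
compound 2, `NS(=O)(=O)c1ccc(C(=O)N/N=C(/CS(=O)(=O)c2ccccc2)c2ccc(F)cc2)cc1`: 63700 nM
compound 3, `NS(=O)(=O)c1ccc(C(=O)N/N=C\c2ccc(Cl)cc2)cc1`: 82000 nM

Compound 1 and compound 2 share a core and differ in one place: fluoro in place of chloro on an aromatic carbon. This change gives a 2.5-fold higher number from compound 1 to compound 2 (0.40 log units; beyond the scatter). Compound 3 carries a different core; the difference between the core of compound 1 and the core of compound 3 is not broken down here. Compound 3 and compound 2 give numbers that lie within the scatter of each other, so nothing is said about their order. Against compound 1, compound 3 gives a number that is higher, beyond the scatter.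

Compound 4, `NS(=O)(=O)c1ccc(C(=O)N/N=C\c2ccc(F)cc2)cc1`, is not yet measured. It is obtained from compound 3 by the same change that leads from compound 1 to compound 2: fluoro in place of chloro on an aromatic carbon. The place of the change is described in the same words in both pairs, so this is the same change, made on a second core.

Among the compounds with values here, only one measured pair carries this change. Within the data shown here, on that basis the step from compound 3 to compound 4 is expected to resemble the earlier one, a 2.0-fold higher number from compound 3 to compound 4 (0.29 log units; within the scatter), because a 2.5-fold higher number from compound 1 to compound 2 (0.40 log units; beyond the scatter) is the single precedent on hand; whether the second core answers in the same way is not known from these compounds. The number expected for compound 4 is 160000 nM, with an estimated range from 60000 nM to 400000 nM.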

Compound 4, half-maximal inhibitory concentration: 35900 nM
Beside the measured number, compound 4's estimate is 4.5-fold (0.65 log units) above it; measured number below the stated range.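

In this assay, fluoro in place of chloro on an aromatic carbon gives a 2.3-fold lower number from compound 3 to compound 4 (0.36 log units; beyond the scatter), so the change from 4-chlorophenyl to 4-fluorophenyl does not carry over from the core of compound 1 with the same direction. The two steps run opposite ways, and the one measured on the first core would have been a poor guide to the second: the same change on two cores in this assay, a 2.5-fold higher number (0.40 log units; beyond the scatter) from compound 1 to compound 2 and a 2.3-fold lower number (0.36 log units; beyond the scatter) from compound 3 to compound 4, 5.7-fold (0.75 log units) apart, beyond the scatter of two such steps

This shows that, in these two pairs, the outcome of this change is tied to the core that carries it, so a step read on one core should not be transferred to the other in this series; it does not show which feature of the cores sets the difference, and two pairs give no rule for any further core.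

The compounds shown leave open how other groups on the same aromatic carbon, such as methyl, methoxy or trifluoromethyl, would behave on each core, and whether they too would part ways between the two. Also open, from the compounds shown here alone, is what happens to either core when the sulfonamide is replaced by a carboxylic acid.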